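Amide side chain series: from compound 3 to compound 4

The compounds below may be only part of what the source reports. "The series", "measured", "known", "first", "only" and "open" are said of these compounds alone.

Among the compounds with values here, the three measured members share one core and differ only in the group on the carbonyl carbon. Compound 1 `C=C(C)C(=O)N(Cc1ccc(OC)c(O)c1)c1cc(OC)c(OC)c(OC)c1` carries 1-methylethenyl there, and in a functional assay on MGC-803 cells (Homo sapiens) for inhibition, read by MTT assay, with a stated time of 48 h (on this read-out lower numbers stand for stronger inhibition and higher numbers for weaker inhibition), compound 1 gives 390 nM. Compound 2 `COc1ccc(CN(C(=O)CBr)c2cc(OC)c(OC)c(OC)c2)cc1O` carries bromomethyl; in this assay compound 2 gives 140 nM, a step of a 2.8-fold lower number from compound 1 to compound 2 (0.44 log units; beyond the scatter). Compound 3 `COCC(=O)N(Cc1ccc(OC)c(O)c1)c1cc(OC)c(OC)c(OC)c1` carries methoxymethyl; in this assay compound 3 gives 79 nM. Compound 3 shows the lowest number of the three, with a 4.9-fold lower number from compound 1 to compound 3 (0.69 log units; beyond the scatter), but the gap a 1.8-fold lower number from compound 2 to compound 3 (0.25 log units; within the scatter) lies within the scatter, so compound 2 and compound 3 cannot be told apart.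

Compound 4 `CCCCC(=O)N(Cc1ccc(OC)c(O)c1)c1cc(OC)c(OC)c(OC)c1` differs from compound 3 by propyl in place of methoxy on a saturated chain carbon bound to a carbonyl carbon. Within the data shown here, no measured step removes the hydrogen-bond acceptor from this chain and puts propyl in its place. Among the measured compounds shown here, the only step at the same position, a 1.8-fold lower number from compound 2 to compound 3 (0.25 log units; within the scatter), is within the scatter, and the two steps that change the whole group, a 2.8-fold lower number from compound 1 to compound 2 (0.44 log units; beyond the scatter) and a 4.9-fold lower number from compound 1 to compound 3 (0.69 log units; beyond the scatter), are modest. For compound 4 in this assay a modest rise in the number is therefore expected, with a step within the scatter remaining plausible. Compound 4 is estimated at 150 nM, within a range of 50 nM to 450 nM. This estimate means an expected step of a 1.9-fold higher number from compound 3 to compound 4 (0.28 log units; within the scatter).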

Compound 4, half-maximal inhibitory concentration: 66 nM
Estimate against measurement, compound 4: 2.3-fold (0.36 log units) above; the range from low to high includes it.
By their numbers in this assay, from the lowest: compounds 4, 3 and 2 (each within the scatter of the next, the first and the last beyond it); then compound 1.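

In this assay, propyl in place of methoxy on a saturated chain carbon bound to a carbonyl carbon gives a 1.2-fold lower number from compound 3 to compound 4 (0.08 log units; within the scatter), so compound 3 and compound 4 cannot be told apart, and this position keeps its number with the hydrogen-bond acceptor of methoxy gone and an all-carbon group in its place. Propyl in place of bromo gives a 2.1-fold lower number from compound 2 to compound 4 (0.33 log units; beyond the scatter), a step beyond the scatter that the close pair of compound 2 and compound 3 did not reveal, although compound 4 and compound 3 remain indistinguishable and the series therefore does not form a clear order among these three. Butyl in place of 1-methylethenyl on a carbonyl carbon gives a 5.9-fold lower number from compound 1 to compound 4 (0.77 log units; beyond the scatter), which makes a third group, and the first purely hydrocarbon one, that improves on compound 1, and no evidence is available to account for any of these steps.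

As far as these compounds go, it remains open whether a longer chain such as hexyl, or a branched group such as tert-butyl, would keep the number in this range. Equally open is how an amine or a carboxylic acid at the end of this chain would read in this assay, since the groups shown carry neither.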